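Swapping Hydroxyphenyl for Chlorophenyl: What Cytotoxicity to Expect

The source may report more compounds than this note shows. Statements on the series, on what has been measured and on what is new or still open speak of the compounds shown alone.

Compound 1 `Cc1c(O)nc(SCc2ccc(O)cc2)nc1Cc1c(Cl)cccc1Cl` has been tested in a functional assay on MT4 cells (Homo sapiens) for cytotoxicity, read by MTT assay; a lower number here means that less compound is tolerated, a higher number that more compound is tolerated. There compound 1 gives 41000 nM. Among the two results gathered so far this is the only one reported as a full number, so compound 1 is the sole fixed point for comparison.

For the measured compounds named here, compound 2 `Cc1c(O)nc(S(=O)(=O)Cc2ccc([N+](=O)[O-])cc2)nc1Cc1c(Cl)cccc1Cl` differs from compound 1 in more than one place, so no single step connects the two. In this assay compound 2 gives > 53000 nM, which is a limit of the assay rather than a measured number.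

Compound 3 `Cc1c(O)nc(SCc2cccc(Cl)c2)nc1Cc1c(Cl)cccc1Cl` is the compound still to be measured. It differs from compound 1 in one place: 3-chlorophenyl in place of 4-hydroxyphenyl on a saturated chain carbon bound to a sulfur. Going by the values given here, no measured pair shows what such a change does in this assay, so the expectation rests on compound 1 alone.

For compound 3 the expected value in this assay is 30000 nM, with a likely range from 10000 nM to 70000 nM. The step of a 1.4-fold lower number from compound 1 to compound 3 (0.14 log units; within the scatter) is expected to stay within the usual scatter, in no clear direction. Because one of the two results already sits at the limit of > 53000 nM in this assay, at which 1 of the 2 values shown sits, a limit instead of a number for compound 3 remains possible.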

Compound 3, half-maximal cytotoxic concentration: > 59000 nM
Compound 3: only a limit was reported; the forecaster's own chance of this, stated with the estimate: 30%; at least 1.9-fold (0.29 log units) between middle value and limit.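

In this assay, replacing 4-hydroxyphenyl with 3-chlorophenyl on a saturated chain carbon bound to a sulfur gives an at least 1.4-fold higher number from compound 1 to compound 3 (0.15 log units; that floor lies within the scatter). Compound 3 has no full number, only a limit of the assay: the limit of > 59000 nM in this assay, at which 1 of the 3 values shown sits. For the compounds shown here, this is the first single-place step at this position, and it shows that the swap brings no sign of greater cytotoxicity, though its floor lies within the scatter, so a real rise in the tolerated concentration is not established.

As far as these compounds go, how far the true value of compound 3 lies past its limit stays open, and with it the real size of the step. The compounds shown also cannot separate the effect of removing the 4-hydroxy group from that of adding the chlorine at the 3 position, and they do not tell whether a 4-chlorophenyl, a phenyl ring carrying a carboxylic acid or an amine, or a longer chain at this place would be tolerated as well.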